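The compounds below may be only part of what the source reports. "The series", "measured", "known", "first", "only" and "open" are said of these compounds alone.

Three compounds share one core and have been run in the same metabolic stability assay. Compound 1 `CC(=O)n1cc(C(=O)O)c(Nc2ccc(I)cc2F)c1C`, compound 2 `CC(=O)c1cc(C(=O)NOCCCO)c(Nc2ccc(I)cc2F)n1C` and compound 3 `CC(=O)c1cc(C(=O)NOC(CO)CO)c(Nc2ccc(I)cc2F)n1C` differ only in the group hanging from the carbonyl carbon on the core. In an in vitro ADME assay on microsomes from liver (Rattus norvegicus) for metabolic stability (a higher number here means that the compound lasts longer, a lower number that the compound disappears faster), compound 1 gives 0.35 h, compound 2 gives 0.217 h and compound 3 gives 0.267 h. Compound 2 has the lowest of the three numbers, but its gap to each of the other two is within the usual scatter, so the three cannot be ordered with confidence. Among the measured compounds shown here, the single one-point step among them, a 1.2-fold higher number from compound 2 to compound 3 (0.09 log units; within the scatter), is likewise within the scatter.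

Compound 4 `CC(=O)c1cc(C(=O)N2CC(N)C2)c(Nc2ccc(I)cc2F)n1C` is the next compound. Its change from compound 2 is 3-aminoazetidin-1-yl in place of (3-hydroxypropoxy)amino on a carbonyl carbon. For the measured compounds named here, no measured step replaces the (3-hydroxypropoxy)amino group with a ring, so the step from compound 2 to compound 3, which only reshapes the chain on the oxygen, is the nearest guide, and it was flat. The expected step is therefore a 1.4-fold higher number from compound 2 to compound 4 (0.14 log units; within the scatter), meaning no change beyond the scatter in this assay. Compound 4 is thus estimated at 0.3 h, between 0.12 h and 0.8 h.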

Compound 4, half-life: 1.07 h
Beside the measured number, compound 4's estimate is 3.6-fold (0.55 log units) below it; the measured number lies above the stated range.
By their numbers in this assay, from the lowest: compounds 2, 3 and 1 (each within the scatter of the next); then compound 4.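

The group on the carbonyl carbon turns out to matter in this assay: reshaping the chain on the oxygen gave only a step within the scatter, whereas swapping the whole group for 3-aminoazetidin-1-yl gives (a 4.9-fold higher number from compound 2 to compound 4 (0.69 log units; beyond the scatter)) and (a 4.0-fold higher number from compound 3 to compound 4 (0.60 log units; beyond the scatter)), so compound 4 lasts longer than either compound with an open chain. This change is a bundle, though: an open chain with oxygen atoms leaves, and a four-membered non-aromatic ring with an amine enters, so the two steps cannot tie the longer half-life to any single one of these features. Nothing available here explains the result, and the data give no mechanism for it.

The compounds shown leave open whether the ring or its amine goes with the higher number, a question that an azetidine carrying a hydroxyl instead of the amine, or an open-chain amine on the same carbonyl carbon, would help to separate. Going by these compounds, whether a larger ring such as a piperidine bearing an amine would behave like the 3-aminoazetidin-1-yl group also remains unknown.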